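Cytotoxicity Stays at the Limit Across Three Amides

The compounds below may be only part of what the source reports. "The series", "measured", "known", "first", "only" and "open" are said of these compounds alone.

Measured so far:
compound 1, `CCOC(=O)CCCCCOc1cccc(CN(C(=O)c2ccccc2)C(C)C)c1`: > 26000 nM
compound 2, `CCOC(=O)CCCCCOc1cccc(CN(C(=O)c2ccc(-c3cccc(N(C)C)c3)cc2)C(C)C)c1`: > 26000 nM
compound 3, `CCOC(=O)CCCCCOc1cccc(CN(C(=O)c2ccc(-c3ccncc3)cc2)C(C)C)c1`: > 26000 nM

All three measured compounds share one core, and all three sit at the limit in an ADME assay on HepG2 cells (Homo sapiens) for cytotoxicity, read by CellTiter-Glo and resazurin assay, with a stated time of 72 h; a lower number here means that less compound is needed, a higher number that more compound is needed for the effect. Compound 1 gives a limit of > 26000 nM in this assay. Compound 2 likewise gives a limit of > 26000 nM. Compound 3 also gives a limit of > 26000 nM. Because of the limit of > 26000 nM in this assay, at which 3 of the 3 values shown sit, none of the steps among them can be read: a step that the two limits leave unreadable from compound 1 to compound 2, a step that the two limits leave unreadable from compound 1 to compound 3 and a step that the two limits leave unreadable from compound 2 to compound 3. Compound 3 thus stands at the limit, exactly where the two other values shown stand as well.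

Compound 4, `CCOC(=O)CCCCCOc1cccc(CN(C(=O)c2ccc(-c3cccc(-c4ccccc4)c3)cc2)C(C)C)c1`, differs from compound 3 by 3-phenylphenyl in place of pyridin-4-yl on an aromatic carbon. The measured steps that bear on this change are the two that exchange the group on the same aromatic carbon, a step that the two limits leave unreadable from compound 1 to compound 3 and a step that the two limits leave unreadable from compound 2 to compound 3, and both are unreadable, so neither size nor direction can be drawn from them. The expected step in this assay is therefore none that can be read, and the estimated step that the limit leaves unreadable from compound 3 to compound 4 rests only on compound 3 remaining at its limit. Compound 4 is estimated at 30000 nM, with a range from 12000 nM to 80000 nM, and a limit rather than a number is the more likely outcome.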

Compound 4, half-maximal effective concentration: > 26000 nM
Compound 4: only a limit was reported; the forecaster's own chance of this, stated with the estimate: 75%; the middle value lies beyond the limit too.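

In this assay compound 4 gives > 26000 nM, which is a limit and not a number. Among these compounds, no step from compound 1, compound 2 or compound 3 to compound 4 can be read, because all four stand at the same limit: the limit of > 26000 nM in this assay, at which 4 of the 4 values shown sit. The compounds shown leave open what number any of the four would give in this assay, and so whether the groups exchanged on the aromatic carbon make any difference there.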